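This account rests on a few compounds, and the source may have more. Where it says the series, first, only, none or still open, it means among the compounds named here.

In a functional assay on K562 cells (Homo sapiens) for cytotoxicity, read by trypan blue exclusion, with a stated time of 96 h (on this read-out higher numbers stand for weaker inhibition and lower numbers for stronger inhibition), three compounds have been measured. Compound 1 `COc1ccc(CS(=O)(=O)/C=C/c2c(OC)cc(O)cc2OC)cc1[N+](=O)[O-]` gives 5000 nM, compound 2 `COc1cc(OC)c(/C=C/S(=O)(=O)Cc2ccc(Br)c(N)c2)c(OC)c1` gives 750 nM, and compound 3 `COC(=O)C(Nc1cc(CS(=O)(=O)/C=C/c2c(OC)cc(OC)cc2OC)ccc1OC)c1ccc(F)cc1` gives 800 nM. Compound 3 thus stands second highest of the three numbers: its value and that of compound 2 lie within the scatter of each other, while compound 1 has a clearly higher number. Compound 4 `COc1cc(OC)c(/C=C/S(=O)(=O)Cc2ccc(OC)c(NC(C(=O)O)c3ccc(Br)cc3)c2)c(OC)c1` is not yet measured; it differs from compound 3 in one place ((4-bromophenyl)(carboxy)methyl in place of (4-fluorophenyl)(methoxycarbonyl)methyl on a nitrogen on an aromatic ring). For the measured compounds named here, no measured pair shows a comparable change, so the step is expected to be small and of uncertain direction no change at the digits printed from compound 3 to compound 4 (within the scatter). Compound 4 is therefore estimated at 800 nM, within a range from 300 nM to 2500 nM.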

Compound 4, half-maximal inhibitory concentration: 200 nM
Estimate against measurement, compound 4: 4.0-fold (0.60 log units) above; measured number outside the range, below it.
By their numbers in this assay, from the lowest: compound 4; then compounds 2 and 3 (each within the scatter of the next); then compound 1.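

In this assay, the group on this nitrogen turns out to matter: (4-bromophenyl)(carboxy)methyl in place of (4-fluorophenyl)(methoxycarbonyl)methyl gives a 4.0-fold lower number from compound 3 to compound 4 (0.60 log units; beyond the scatter), which means stronger inhibition. No earlier pair had shown what a change at this place does. Nothing available here explains the step. The change swaps fluorine for bromine and the methyl ester for a carboxylic acid together, so the compounds shown do not separate the two. Going by these compounds, how a primary amide in place of the carboxy, or chlorine in place of the bromine, would read remains open.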